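The compounds below may be only part of what the source reports. "The series", "measured", "known", "first", "only" and "open" are said of these compounds alone.

Working notes on the carbamate series.

Compound 3 `Cc1nc(S(C)(=O)=O)ccc1Oc1ncnc(OC2CCN(C(=O)OC3(C(F)(F)F)COC3)CC2)c1F` sits second highest of the three numbers measured in a functional assay on isolated protein for inhibition of Glucose-dependent insulinotropic receptor (Homo sapiens), read by HTRF and cAMP accumulation (on this read-out higher numbers stand for an effect only at larger amounts of compound and lower numbers for an effect already at smaller amounts), where compound 3 gives 29.3 nM. Its nearest neighbour is compound 1 `Cc1nc(S(C)(=O)=O)ccc1Oc1ncnc(OC2CCN(C(=O)OC(C)(C)CF)CC2)c1F`, which in this assay gives 19.9 nM; the gap is a 1.5-fold higher number from compound 1 to compound 3 (0.17 log units; within the scatter). Compound 2 `Cc1nc(S(C)(=O)=O)ccc1Oc1ncnc(OC2CCN(C(=O)OC(C)F)CC2)c1F` gives 65.5 nM, and the step is a 2.2-fold lower number from compound 2 to compound 3 (0.35 log units; beyond the scatter).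

Compound 4 `Cc1nc(S(C)(=O)=O)ccc1Oc1ncnc(OC2CCN(C(=O)SC(C)C)CC2)c1F` differs from compound 3 at the same position that varies across the measured set: isopropylsulfanyl in place of (3-(trifluoromethyl)oxetan-3-yl)oxy on a carbonyl carbon. Among the compounds with values here, two measured steps bear on changes at this point. Exchanging one substituent for another on the oxygen beside the carbonyl gave a 3.3-fold higher number from compound 1 to compound 2 (0.52 log units; beyond the scatter) when the smaller 1-fluoroethyl entered, and a 1.5-fold higher number from compound 1 to compound 3 (0.17 log units; within the scatter) for the oxetane; those two steps mark out the whole of the variation seen so far at this position. The move to isopropylsulfanyl is a larger change than any of those, removing the ring and all fluorines, and the smaller group in compound 2 went to a higher number. A modest rise is therefore expected, estimated as a 1.9-fold higher number from compound 3 to compound 4 (0.27 log units; within the scatter). Compound 4 is expected to give about 55 nM in this assay, in the range 20 nM to 160 nM.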

Compound 4, half-maximal effective concentration: 6.8 nM
For compound 4 the middle estimate is 8.1-fold (0.91 log units) above the measured one, and the stated range ends above it.
By their numbers in this assay, from the lowest: compound 4; then compounds 1 and 3 (each within the scatter of the next); then compound 2.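

In this assay, isopropylsulfanyl on a carbonyl carbon gives the lowest number of the four compounds, with a 4.3-fold lower number from compound 3 to compound 4 (0.63 log units; beyond the scatter), a 2.9-fold lower number from compound 1 to compound 4 (0.47 log units; beyond the scatter) and a 9.6-fold lower number from compound 2 to compound 4 (0.98 log units; beyond the scatter). The position therefore accepts a group with sulfur on the carbonyl carbon, no ring and no fluorine, and this group goes below everything reached with the three fluorinated groups attached through oxygen. Nothing shown gives a reason for this direction of change.

Compound 4 differs from the others in both the atom on the carbonyl carbon and the group carried on it, so the two contributions cannot be separated here. An isopropoxy group on the same carbonyl carbon would separate them, and a tert-butylsulfanyl group would show whether a larger chain on sulfur keeps the low number.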